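A few compounds are considered here, and "the series" means these few. Any claim that something is new, unique, unknown or untested is made for them only; others in the source may bear on it.

In a physicochemical assay for solubility, in phosphate buffer, at pH 7.4; on this read-out lower numbers stand for lower solubility and higher numbers for higher solubility:
- compound 1 `COCC1CCN(c2nccnc2OC2CN(c3ccc4ccccc4n3)C2)CC1`: 53000 nM
- compound 2 `Cc1ncccc1-c1nccnc1OC1CN(c2ccc3ccccc3n2)C1`: 253000 nM

Compound 2, at 253000 nM, holds the higher of the two numbers. Compound 3 `c1ccc2ncc(-c3nccnc3OC3CN(c4ccc5ccccc5n4)C3)cc2c1` carries quinolin-3-yl in place of 2-methylpyridin-3-yl on an aromatic carbon. Among the measured compounds shown here, one measured step bears on this, a modest one at the same substituent: a 4.8-fold higher number from compound 1 to compound 2 (0.68 log units; beyond the scatter). That step does not involve quinolin-3-yl, so it offers only a guide to size. A move down from the top of this assay of similar size is expected: a 4.2-fold lower number from compound 2 to compound 3 (0.62 log units; beyond the scatter). For compound 3 the estimated value is 60000 nM, with an expected range of 12000 nM to 200000 nM.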

Compound 3, solubility: < 1000 nM
Compound 3 was reported as a limit; the forecaster's own chance of this, stated with the estimate: 5%; middle value at least 60-fold (1.77 log units) from the limit.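

In this assay, the position on the aromatic carbon next to the ring nitrogen proves far more sensitive than the first pair suggested: quinolin-3-yl gives an at least 250-fold lower number from compound 2 to compound 3 (2.40 log units; beyond the scatter), and an at least 53-fold lower number from compound 1 to compound 3 (1.72 log units; beyond the scatter). The second ring at this place therefore accompanies the lowest reading of the three compounds. Compound 3 gives < 1000 nM, which is a limit and not a number, so both steps are bounds: the limit of < 1000 nM in this assay, at which 1 of the 3 values shown sits.

The compounds shown do not separate the added ring of carbon from the loss of the methyl group. From the compounds shown here alone, how an unsubstituted pyridine ring or a morpholine would read at this place remains open.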